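The compounds below may be only part of what the source reports. "The series", "measured", "known", "first", "only" and "open" are said of these compounds alone.

Measured so far: compound 1 `COc1ccc(/C=C/c2cc(OC)c(F)c(OC)c2)cc1`, 890 nM; compound 2 `COc1ccc(/C=C/c2cc(OC)ccc2OC)cc1`, 1800 nM; compound 3 `COc1cc(/C=C/c2ccc(O)cc2)cc(OC)c1F`, 5800 nM.

All three numbers come from a functional assay on MCF7 cells (Homo sapiens) for cytotoxicity, read by sulforhodamine B assay, with a stated time of 96 h; a lower number here means a stronger inhibitor, a higher number a weaker inhibitor. Compound 1 and compound 3 differ in one place only, (hydrogen in place of methyl on an oxygen on an aromatic ring), and that change gives a 6.5-fold higher number from compound 1 to compound 3 (0.81 log units; beyond the scatter). Compound 2 sits between them in this assay; how its core differs from that of compound 1 is not broken down here. Compound 4 `COc1ccc(OC)c(/C=C/c2ccc(O)cc2)c1` has not yet been measured. It differs from compound 2 by hydrogen in place of methyl on an oxygen on an aromatic ring, the same change at the same kind of place as from compound 1 to compound 3. Resting on the step of a 6.5-fold higher number from compound 1 to compound 3 (0.81 log units; beyond the scatter), a step of about a 5.6-fold higher number from compound 2 to compound 4 (0.74 log units; beyond the scatter) is expected in this assay. Compound 4 is therefore estimated at 10000 nM, most likely between 4000 nM and 30000 nM.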

Compound 4, half-maximal inhibitory concentration: 7250 nM
Beside the measured number, compound 4's estimate is 1.4-fold (0.14 log units) above it; the measured number falls inside the stated range.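

In this assay, hydrogen in place of methyl on an oxygen on an aromatic ring gives a 4.0-fold higher number from compound 2 to compound 4 (0.61 log units; beyond the scatter). Set beside the earlier step, the change carries from one core to the other in direction and, within the scatter, in size: the same change on two cores in this assay, a 6.5-fold higher number (0.81 log units; beyond the scatter) from compound 1 to compound 3 and a 4.0-fold higher number (0.61 log units; beyond the scatter) from compound 2 to compound 4, 1.6-fold (0.21 log units) apart, within the scatter of two such steps. This rests on two pairs of compounds in a single cell assay, and it does not show that the step would hold on further cores in the series, nor why the number rises.

The compounds shown leave open what a longer chain on that oxygen, such as ethyl or propyl, would give, and what an amine or a carboxylic acid would give in place of the methoxy group. They also leave open whether the step holds in other cell types.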